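Lengthening the Amide Chain of Compound 1

The source may hold more compounds than are shown below. What is called first, only, known or untested is meant among the compounds shown, and "the series" means these compounds.

In a functional assay on SN12C cells (Homo sapiens) for cytotoxicity (a higher number here means a weaker inhibitor of growth, a lower number a stronger inhibitor of growth), compound 1 (`CCCCCCNC(=O)c1cc(NCc2cc(O)ccc2O)ccc1O`) gives 6100 nM and lies within the scatter of compound 2 (`O=C(NCc1ccccc1)c1cc(NCc2cc(O)ccc2O)ccc1O`), which gives 12000 nM on the same read-out, so neither number stands apart. Compound 3 (`CCCCCCCCCCCCNC(=O)c1cc(NCc2cc(O)ccc2O)ccc1O`) keeps the shared core and extends the chain, the difference being hexyl in place of hydrogen on a saturated chain carbon, six bonds along the chain from an amide-type nitrogen with the rest of compound 1 unchanged. Among the measured compounds shown here, only one measured step touches this chain (a 2.0-fold higher number from compound 1 to compound 2 (0.29 log units; within the scatter)), and it exchanges pentyl for phenyl without lengthening anything. For the measured compounds named here, no measured compound carries a chain this long, so the evidence is thin and the range must stay wide. Going by the values given here, with that single small step as the only guide, no shift beyond the scatter is expected in this assay and no firm direction can be given. The expected change is a 1.2-fold lower number from compound 1 to compound 3 (0.09 log units; within the scatter) and no more can be claimed. For compound 3 the estimated value is 5000 nM with an expected range of 1500 nM to 17000 nM on this read-out.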

Compound 3, concentration for 50% growth inhibition: 2600 nM
Compound 3: the middle estimate sits 1.9-fold (0.28 log units) above what was measured; low and high end bracket the measured number.
By their numbers in this assay, from the lowest: compound 3; then compounds 1 and 2 (each within the scatter of the next).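

In this assay, hexyl in place of hydrogen on a saturated chain carbon, six bonds along the chain from an amide-type nitrogen, gives a 2.3-fold lower number from compound 1 to compound 3 (0.37 log units; beyond the scatter) and so moves the number beyond the scatter. Among the compounds shown here, the earlier step, a 2.0-fold higher number from compound 1 to compound 2 (0.29 log units; within the scatter), stayed within the scatter, so this is the first sign that the number responds to a change at this position, and the response to the added hexyl is modest. Nothing available explains why the number moves with this change.

Going by these compounds, it remains open whether a still longer chain, such as hexadecyl, would lower the number further, or whether a butyl chain would fit the same trend. Also open, on these data alone, is whether an amine or a carboxylic acid carried on this chain would keep the number as low.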